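The source may hold more compounds than are shown below. What is called first, only, known or untested is meant among the compounds shown, and "the series" means these compounds.

Compound 1, `Cc1cc(S(=O)(=O)/N=C(\N)n2nccc2-c2ccccc2)c(SCc2ccccc2)cc1Cl`: in a functional assay on MCF7 cells (Homo sapiens) for cytotoxicity, read by MTT assay, with a stated time of 72 h (on this read-out lower numbers stand for stronger inhibition and higher numbers for weaker inhibition), compound 1 gives 20000 nM.
Compound 2, `Cc1cc(S(=O)(=O)/N=C(\N)n2nccc2-c2ccccc2)c(SCc2cccc(C(F)(F)F)c2)cc1Cl`: in this assay compound 2 gives 17000 nM.

Compound 2 holds the lower of the two numbers, but the step of a 1.2-fold lower number from compound 1 to compound 2 (0.07 log units; within the scatter) lies within the scatter, so the two compounds cannot be told apart on these data. Compound 3, `Cc1ccc(CSc2cc(Cl)c(C)cc2S(=O)(=O)/N=C(\N)n2nccc2-c2ccccc2)cc1`, differs from compound 2 in one place: 4-methylphenyl in place of 3-(trifluoromethyl)phenyl on a saturated chain carbon bound to a sulfur. Among the measured compounds shown here, the only measured step touching this ring, a 1.2-fold lower number from compound 1 to compound 2 (0.07 log units; within the scatter), stayed within the scatter, so no step beyond the scatter is expected here. Compound 3 is therefore expected to give 18000 nM, within a range from 8000 nM to 40000 nM, which means an expected step of a 1.1-fold higher number from compound 2 to compound 3 (0.02 log units; within the scatter).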

Compound 3, half-maximal inhibitory concentration: 21000 nM
For compound 3 the middle estimate is 1.2-fold (0.07 log units) below the measured one; the measured number falls inside the stated range.
By their numbers in this assay, from the lowest: compounds 2, 1 and 3 (each within the scatter of the next).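

In this assay, 4-methylphenyl in place of 3-(trifluoromethyl)phenyl on the saturated chain carbon bound to a sulfur gives a 1.2-fold higher number from compound 2 to compound 3 (0.09 log units; within the scatter) and so makes no readable difference. Methyl in place of hydrogen on an aromatic carbon of this ring gives a 1.1-fold higher number from compound 1 to compound 3 (0.02 log units; within the scatter) and is likewise unreadable, so trifluoromethyl is no longer the only ring group shown to stay within the scatter. Nothing available explains this result.

Still open, from the compounds shown here alone, is whether an amine or a carboxylic acid on this ring would give a step beyond the scatter.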